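From Methoxy to Hydroxy on Compound 1

The compounds below may be only part of what the source reports. "The series", "measured", "known", "first", "only" and "open" are said of these compounds alone.

In a physicochemical assay, read by spectrophotometry, with a stated time of 15 min (a lower number here means a stronger inhibitor, a higher number a weaker inhibitor), compound 1 (`COc1cc(/C=N/NC(=O)CCc2nc3ccccc3c(=O)[nH]2)cc(OC)c1OC`) gives 80000000 nM and compound 2 (`COc1cc(/C=N/NC(=O)CCCc2nc3ccccc3c(=O)[nH]2)cc(OC)c1OC`) gives 85000000 nM, so the two stand within the scatter of each other. Compound 3 (`COc1cc(/C=N/NC(=O)CCc2nc3ccccc3c(=O)[nH]2)cc(OC)c1O`) departs from compound 1 at one place: hydrogen in place of methyl on an oxygen on an aromatic ring, or methoxy to hydroxy. Within the data shown here, no measured pair shows this change, so the expectation is a judgement. A large estimated step, a 40-fold lower number from compound 1 to compound 3 (1.60 log units; beyond the scatter), is expected toward a stronger inhibitor, well beyond the scatter. Compound 3 is expected to give about 2000000 nM, within an estimated range of 100000 nM to 30000000 nM.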

Compound 3, half-maximal inhibitory concentration: 275000000 nM
Compound 3: the middle estimate sits 140-fold (2.14 log units) below what was measured; measured number outside the range, above it.
By their numbers in this assay, from the lowest: compounds 1 and 2 (each within the scatter of the next); then compound 3.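

In this assay, the change from methoxy to hydroxy gives a 3.4-fold higher number from compound 1 to compound 3 (0.54 log units; beyond the scatter), a modest move toward a weaker inhibitor. Among these compounds, compound 1 and compound 2 both carry methoxy at this place, so only this step shows that the methyl on the oxygen on an aromatic ring matters to the read-out. Nothing available explains the shift.

Going by these compounds, whether an ethoxy group, a longer alkoxy chain or an amine at this place would give a stronger or weaker inhibitor remains open. So does whether methoxy to hydroxy would have the same effect on compound 2.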